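Phenyl in Place of Pyridin-4-yl: Expecting Compound 3

The compounds below may be only part of what the source reports. "The series", "measured", "known", "first", "only" and "open" are said of these compounds alone.

Compound 1 `O=C(CN1CCN(c2nnc(Cc3ccncc3)c3ccccc23)CC1)Nc1cccc(Br)c1`: 1530 nM
Compound 2 `O=C(CN1CCN(c2nnc(Cc3ccncc3)c3ccccc23)CC1)Nc1c(F)cccc1F`: 54400 nM

For the measured compounds named here, in a functional assay on A549 cells (Homo sapiens) for cytotoxicity, read by MTT assay, with a stated time of 72 h (a lower number here means a stronger inhibitor, a higher number a weaker inhibitor), compound 1 gives 1530 nM, the lowest of the two numbers measured so far. Going by the values given here, compound 2 gives 54400 nM, and the single recorded step, a 36-fold higher number from compound 1 to compound 2 (1.55 log units; beyond the scatter), concerns only the aryl group on the amide-type nitrogen. Compound 3 `O=C(CN1CCN(c2nnc(Cc3ccccc3)c3ccccc23)CC1)Nc1cccc(Br)c1` keeps the 3-bromophenyl on that nitrogen unchanged and differs from compound 1 at another spot: phenyl in place of pyridin-4-yl on a saturated chain carbon bound to an aromatic carbon. Among the compounds with values here, no measured pair touches this part of the shared core, so the one recorded step does not bear on the change; it shows only that this series can move a great deal when a group elsewhere is altered. With nothing pointing either way, the expected step of a 1.0-fold lower number from compound 1 to compound 3 (0.01 log units; within the scatter) is taken as none beyond the scatter. Compound 3 is therefore estimated at 1500 nM, with a range from 400 nM to 6000 nM.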

Compound 3, half-maximal inhibitory concentration: "not active" (no number reported)
The entry for compound 3 holds no number, so the estimate cannot be set against anything.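

For the compounds shown here, compound 3 is recorded only as "not active", with no number, so no step from compound 1 to compound 3 can be read. No measurement at hand offers an explanation for this result. As far as these compounds go, how far phenyl in place of pyridin-4-yl moves the number remains open.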